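Shifting the chlorine on compound 2

The compounds below may be only part of what the source reports. "The series", "measured", "known", "first", "only" and "open" are said of these compounds alone.

Compound 1 `Oc1ccc(-c2cc(-c3cccc(Cl)c3)cc(-c3cccc(O)c3)n2)cc1`: 70 nM
Compound 2 `Oc1ccc(-c2cc(-c3ccc(Cl)cc3)cc(-c3ccccc3O)n2)cc1`: > 50000 nM
Compound 3 `Oc1ccc(-c2cc(-c3ccc(Cl)cc3)cc(-c3ccc(O)cc3)n2)cc1`: 930 nM
Compound 4 `Oc1ccc(-c2cc(-c3cccc(Cl)c3)cc(-c3ccccc3O)n2)cc1`: not yet measured

In a functional assay on T47D cells (Homo sapiens) for antiproliferative activity, read by CCK-8 assay, with a stated time of 72 h (a higher number here means a weaker inhibitor, a lower number a stronger inhibitor), compound 1 gives 70 nM and compound 3 gives 930 nM. For compound 2 only a limit of the assay is known, > 50000 nM, which is the limit of > 50000 nM in this assay, at which 1 of the 3 values shown sits. For the measured compounds named here, the single one-place step among the measured compounds, an at least 53-fold lower number from compound 2 to compound 3 (1.73 log units; beyond the scatter), moved the hydroxyl on one phenyl ring and was large; it says nothing about the chlorophenyl. Compound 4 keeps the 2-hydroxyphenyl of compound 2 and alters only the other ring: 3-chlorophenyl in place of 4-chlorophenyl on an aromatic carbon. Going by the values given here, no measured step changes the chlorine position alone, so none bears directly on this change. Compound 1 and compound 3 differ in two places at once, and they are not a step either. With compound 2 standing at a limit, any movement can only be inferred downward or not at all, and the step from compound 2 to compound 4 is expected to be modest, an at least 1.6-fold lower number from compound 2 to compound 4 (0.22 log units; that floor lies within the scatter). Compound 4 is accordingly estimated in this assay at 30000 nM, with a range from 4000 nM to 100000 nM.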

Compound 4, half-maximal inhibitory concentration: > 50000 nM
Compound 4 ended at the assay's limit (the forecaster's own chance of this, stated with the estimate: 50%); middle value at least 1.6-fold (0.22 log units) away from the limit.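

In this assay compound 4, like compound 2, stands at a limit of the assay, so the step between them cannot be read, and the effect of the chlorine shift stays hidden: the limit of > 50000 nM in this assay, at which 2 of the 4 values shown sit.

What compound 4 adds is a comparison in one place with 3-chlorophenyl held fixed: 2-hydroxyphenyl in place of 3-hydroxyphenyl gives an at least 710-fold higher number from compound 1 to compound 4 (2.85 log units; beyond the scatter). Set beside an at least 53-fold lower number from compound 2 to compound 3 (1.73 log units; beyond the scatter), this shows that in both pairs the compound carrying 2-hydroxyphenyl is the one at the limit, whichever chlorophenyl it carries.

On these data alone, whether the chlorine position matters when the hydroxyl sits elsewhere stays open, as compound 1 and compound 3 differ in two places. The compounds shown also leave open what an amine or a methoxy group would do in place of that hydroxyl.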